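Benzyl fluorine pattern versus cytotoxicity in the shared core

The source may report more compounds than this note shows. Statements on the series, on what has been measured and on what is new or still open speak of the compounds shown alone.

Measured so far:
compound 1 `CCOC(=O)/C(O)=C/C(=O)c1cn(Cc2ccccc2F)c2cccc(OC)c12` – 63300 nM
compound 2 `CCOC(=O)/C(O)=C/C(=O)c1cn(Cc2c(F)ccc(F)c2F)c2cccc(OC)c12` – 40500 nM

In an ADME assay on MT4 cells (Homo sapiens) for cytotoxicity, read by MTT assay (on this read-out lower numbers stand for higher toxicity in this test and higher numbers for lower toxicity in this test), compound 2 holds the lowest of the two numbers; its nearest neighbour is compound 1, the step of a 1.6-fold lower number from compound 1 to compound 2 (0.19 log units; within the scatter) being within the scatter. Compound 3 `CCOC(=O)/C(O)=C/C(=O)c1cn(Cc2cc(F)ccc2F)c2cccc(OC)c12` differs from compound 2 by hydrogen in place of fluoro on an aromatic carbon. Among the compounds with values here, the only step that bears on it is the one from compound 1 to compound 2, which also alters the fluorine pattern on the benzyl group and stays within the scatter. No step beyond the scatter is therefore expected in this assay; the estimated step is a 1.2-fold higher number from compound 2 to compound 3 (0.09 log units; within the scatter). Compound 3 is estimated at 50000 nM, range 22000 nM to 115000 nM.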

Compound 3, half-maximal cytotoxic concentration: 41200 nM
Compound 3: the middle estimate sits 1.2-fold (0.08 log units) above what was measured, within the range that was stated.
By their numbers in this assay, from the lowest: compounds 2, 3 and 1 (each within the scatter of the next).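

In this assay the change from 2,3,6-trifluorobenzyl to 2,5-difluorobenzyl gives a 1.0-fold higher number from compound 2 to compound 3 (0.01 log units; within the scatter) and so leaves the read-out unmoved at this position. The step of a 1.5-fold lower number from compound 1 to compound 3 (0.19 log units; within the scatter) also stays within the scatter, so the three fluorine patterns on the benzyl group cannot be told apart in this test. Nothing available explains this flat result. Open, going by these compounds, is whether a benzyl group carrying no fluoro, or one carrying chloro or methoxy, would read the same. Also open, on these data alone, is the effect of a carboxylic acid in place of the ethyl ester.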